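The source may hold more compounds than are shown below. What is called first, only, known or untested is meant among the compounds shown, and "the series" means these compounds.

Going by the values given here, in an ADME assay on S9 fraction from liver (Homo sapiens) for metabolic stability, using NADPH, in the presence of a further agent that is not named here (on this read-out higher numbers stand for a longer-lived compound and lower numbers for a shorter-lived compound), compound 1 `Cc1cccc(S(=O)(=O)Nc2cccc(-c3ccc(C(=O)c4cc(F)c(F)c(O)c4F)s3)c2)c1` gives 0.467 h and compound 2 `O=C(c1ccc(-c2cccc(NS(=O)(=O)c3cccc(Cl)c3)c2)s1)c1cc(F)c(F)c(O)c1F` gives 0.7 h; the step of a 1.5-fold higher number from compound 1 to compound 2 (0.18 log units; within the scatter) is the only measured one between neighbours. Compound 3 `O=C(c1ccc(-c2cccc(NS(=O)(=O)c3ccccc3)c2)s1)c1c(F)ccc(O)c1Cl` reaches only the assay limit < 0.0834 h in this assay, which is a limit rather than a number (the limit of < 0.0834 h in this assay, at which 1 of the 3 values shown sits). Compound 4 `O=C(c1ccc(-c2cccc(NS(=O)(=O)c3ccccc3)c2)s1)c1cccc(O)c1Cl` differs from compound 3 by hydrogen in place of fluoro on an aromatic carbon. Among the compounds with values here, no measured step touches that change, and the single measured step sits within the scatter, so these data give no reason to expect a move in this assay in either direction beyond the scatter. Compound 4 is therefore expected to stay close to the same limit, the step that the limit leaves unreadable from compound 3 to compound 4 being the estimated one. The estimate for compound 4 is 0.08 h, in the range 0.03 h to 0.25 h.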

Compound 4, half-life: < 0.0834 h
Compound 4 ended at the assay's limit; the forecaster's own chance of this, stated with the estimate: 60%; the middle value is on the limit's open side.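

Compound 3 and compound 4 both stand at a limit of this assay, so no step between them can be read: the limit of < 0.0834 h in this assay, at which 2 of the 4 values shown sit.

The compounds shown leave open whether hydrogen in place of fluoro, going from 2-chloro-6-fluoro-3-hydroxyphenyl to 2-chloro-3-hydroxyphenyl, changes the half-life at all.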